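Methoxy in Place of Fluoro on the Aromatic Ring

The source may hold more compounds than are shown below. What is called first, only, known or untested is meant among the compounds shown, and "the series" means these compounds.

Compound 2 `COc1cc(C(F)(F)F)cc(SC)c1C(=O)NC1(c2cccc(F)c2)CCCN(C)C1` gives 48 nM in an assay on cells for inhibition of sodium- and chloride-dependent glycine transporter 1 (Homo sapiens) (on this read-out higher numbers stand for an effect only at larger amounts of compound and lower numbers for an effect already at smaller amounts), the higher of the two numbers seen so far. Going by the values given here, its nearest neighbour is compound 1 `COc1cc(C(F)(F)F)cc(SC)c1C(=O)NC1(c2ccc(Cl)cc2)CCCN(C)C1`, which gives 28 nM; the one measured step is a 1.7-fold higher number from compound 1 to compound 2 (0.23 log units; within the scatter). Compound 3 `COc1cccc(C2(NC(=O)c3c(OC)cc(C(F)(F)F)cc3SC)CCCN(C)C2)c1` is not yet measured and differs from compound 2 by methoxy in place of fluoro on an aromatic carbon. Among the compounds with values here, only that single step concerns a change on the same aromatic ring, and it stayed within the scatter, so no step beyond the scatter is expected in this assay. Compound 3 is therefore estimated at 60 nM, between 25 nM and 150 nM, which means a 1.3-fold higher number from compound 2 to compound 3 (0.10 log units; within the scatter).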

Compound 3, half-maximal effective concentration: 110 nM
Compound 3: middle estimate off by 1.8-fold (0.26 log units), on the low side; low and high end bracket the measured number.
By their numbers in this assay, from the lowest: compounds 1 and 2 (each within the scatter of the next); then compound 3.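

In this assay, going by these compounds alone, methoxy in place of fluoro on an aromatic carbon gives a 2.3-fold higher number from compound 2 to compound 3 (0.36 log units; beyond the scatter) and so moves the number beyond the scatter, which the one earlier step did not do. Set against the 4-chlorophenyl of compound 1, the 3-methoxyphenyl gives a 3.9-fold higher number from compound 1 to compound 3 (0.59 log units; beyond the scatter) and so compound 3 stands apart from both earlier compounds. Nothing available explains this shift. Going by these compounds, it stays open whether an amine, a hydroxyl or a chlorine on this aromatic carbon would read like fluoro or like methoxy. Whether a longer chain such as ethoxy would carry the step further also remains unsettled.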